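The source may hold more compounds than are shown below. What is called first, only, known or untested is meant among the compounds shown, and "the series" means these compounds.

Series notes. The shared core is carried by compound 1 `CC(=O)NC[C@H]1CN(c2ccc(OC[C@@H](O)CNc3ccccc3)c(F)c2)C(=O)O1`, compound 2 `CC(=O)NC[C@H]1CN(c2ccc(OC[C@@H](O)CNc3ccccn3)c(F)c2)C(=O)O1` and compound 3 `CC(=O)NC[C@H]1CN(c2ccc(OC[C@@H](O)CNCCC(C)C)c(F)c2)C(=O)O1`; compound 4 `CC(=O)NC[C@H]1CN(c2ccc(OC[C@H](O)CNCCC(C)C)c(F)c2)C(=O)O1` has not yet been measured. In a physicochemical assay for solubility, read by HPLC (a higher number here means a more soluble compound, a lower number a less soluble compound), compound 2 gives 22200000 nM, the highest of the three numbers. In this assay compound 1 gives 124000 nM, and compound 3 gives 385000 nM. Relative to compound 2 the steps are a 180-fold higher number from compound 1 to compound 2 (2.25 log units; beyond the scatter) and a 58-fold lower number from compound 2 to compound 3 (1.76 log units; beyond the scatter); between the other two the step is a 3.1-fold higher number from compound 1 to compound 3 (0.49 log units; beyond the scatter).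

The change from compound 2 to compound 4 is 1-hydroxy-2-(isopentylamino)ethyl in place of 1-hydroxy-2-((pyridin-2-yl)amino)ethyl on a saturated chain carbon bound to an oxygen on an aromatic ring. The step that bears on it most directly is a 58-fold lower number from compound 2 to compound 3 (1.76 log units; beyond the scatter); compound 3 carries the same entering group. Within the data shown here, the stereocentre counted in both groups remains a point of difference between compound 3 and compound 4, and no step is recorded for that pair, so once compound 4 is measured only the two values themselves can be set side by side. Because of a 58-fold lower number from compound 2 to compound 3 (1.76 log units; beyond the scatter) a large drop in this assay is expected for this change, of about a 56-fold lower number from compound 2 to compound 4 (1.74 log units; beyond the scatter). Compound 4 is therefore estimated at 400000 nM, with a range of 130000 nM to 1500000 nM.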

Compound 4, solubility: 7280000 nM
Beside the measured number, compound 4's estimate is 18-fold (1.26 log units) below it, and the stated range ends below it.
By their numbers in this assay, from the lowest: compound 1; then compound 3; then compound 4; then compound 2.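

In this assay the configuration at the stereocentre of the saturated chain carbon has a large effect of its own (a 19-fold higher number from compound 3 to compound 4 (1.28 log units; beyond the scatter)), and this step can be assigned to that inversion alone: the fact that compounds 3 and 4 differ only in the configuration as drawn. Compounds 1, 2 and 3 are all drawn with one configuration at this carbon, so they could show only what the group on the amine nitrogen does, whereas this position now has to be read as two variables, the group and the configuration. The other two new steps (a 3.0-fold lower number from compound 2 to compound 4 (0.48 log units; beyond the scatter) and a 59-fold higher number from compound 1 to compound 4 (1.77 log units; beyond the scatter)) each combine a change of that group with the inverted stereocentre, so neither gives the size of either change separately.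

As far as these compounds go, whether the same inversion moves the number as far with phenyl or pyridin-2-yl on the amine nitrogen remains open, so it is also unknown whether the effect of configuration depends on the group. From the compounds shown here alone, how a cyclohexyl group or a longer alkyl chain on that nitrogen would behave in either configuration is equally open.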